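Taking the Hydroxy Away from Compound 2

The source may hold more compounds than are shown below. What is called first, only, known or untested is meant among the compounds shown, and "the series" means these compounds.

Measured so far in a functional assay on KB cells (Homo sapiens) for antiproliferative activity, read by sulforhodamine B assay, with a stated time of 3 days; a higher number here means that more compound is needed for the effect, a lower number that less compound is needed:
compound 1 `CCC1=C(O)c2c(oc(-c3ccc(F)cc3)cc2=O)C(CC)(CC)C1=O`: 33 uM
compound 2 `CCC1=C(O)c2c(oc(-c3ccc(O)c(C)c3C)cc2=O)C(CC)(CC)C1=O`: 6.5 uM

Compound 2 holds the lower of the two numbers in this assay, at 6.5 uM. For the measured compounds named here, the only measured step, a 5.1-fold lower number from compound 1 to compound 2 (0.71 log units; beyond the scatter), put 4-hydroxy-2,3-dimethylphenyl in place of 4-fluorophenyl on an aromatic carbon. Compound 3 `CCC1=C(O)c2c(oc(-c3cccc(C)c3C)cc2=O)C(CC)(CC)C1=O` has hydrogen in place of hydroxy on an aromatic carbon, turning 4-hydroxy-2,3-dimethylphenyl into 2,3-dimethylphenyl: hydrogen in place of hydroxy on an aromatic carbon. Going by the values given here, the measured step bears on this only in part: it also brought in the methyl groups, and no measured pair isolates the hydroxy. On the strength of a 5.1-fold lower number from compound 1 to compound 2 (0.71 log units; beyond the scatter), a modest rise in the number is expected in this assay, smaller than that step. The expected change is a 2.2-fold higher number from compound 2 to compound 3 (0.33 log units; beyond the scatter). Compound 3 is estimated at 14 uM, with an expected range of 5 uM to 40 uM.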

Compound 3, concentration for half-maximal effect: 3.1 uM
Beside the measured number, compound 3's estimate is 4.5-fold (0.65 log units) above it, outside the stated range (below it).
By their numbers in this assay, from the lowest: compound 3; then compound 2; then compound 1.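

In this assay, the hydroxy on the aromatic ring proves dispensable at this position, since replacing it with hydrogen gives a 2.1-fold lower number from compound 2 to compound 3 (0.32 log units; beyond the scatter). The lower number seen earlier with 4-hydroxy-2,3-dimethylphenyl therefore does not depend on the hydroxy, and 2,3-dimethylphenyl alone in place of 4-fluorophenyl gives an 11-fold lower number from compound 1 to compound 3 (1.03 log units; beyond the scatter). No measurement is available to explain why losing the hydroxy lowers the number.

The compounds shown do not separate the contributions of the two methyl groups, as both are present in compound 2 and compound 3 and neither appears alone. They also leave open whether a methoxy group or an amine in place of the hydroxy would give a number closer to that of compound 2 or compound 3.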